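Adding an Isopropyl Group: Expected Shift in Lipophilicity

The source may hold more compounds than are shown below. What is called first, only, known or untested is meant among the compounds shown, and "the series" means these compounds.

Compound 1 `c1ccc(NC2=NCCC3(CCCCC3)S2)cc1`: 1.02
Compound 2 `Cc1cc(C)c(NC2=NCCC3(CCCCC3)S2)c(C)c1`: 2.05

Of the compounds shown here, two sharing the same core have been measured so far. In a physicochemical assay for lipophilicity, measured as octanol-water partition, at pH 7.4 (a lower number here means a more polar compound, a higher number a more lipophilic compound), compound 1 gives 1.02, the lowest of the two numbers at hand. The nearest value belongs to compound 2, which in this assay gives 2.05, a number that lies higher by more than the usual scatter of repeated measurements; compound 2 differs from compound 1 in carrying three methyl groups.

Compound 3 `CC(C)c1ccc(NC2=NCCC3(CCCCC3)S2)cc1` has not yet been measured in this assay. It is compound 1 with one change: isopropyl in place of hydrogen on an aromatic carbon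

Among the measured compounds shown here, no step between two measured compounds describes exactly this change, so the expectation rests on the two values known. The step of a number 1.18 log units higher from compound 1 to compound 3 (beyond the scatter) is expected to run upward and to exceed the scatter. On this basis compound 3 is expected to give 2.2 in this assay, with a likely range from 1.7 to 2.7.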

Compound 3, distribution coefficient: 1.57
Beside the measured number, compound 3's estimate is 0.63 log units above it, and the stated range ends above it.
By their numbers in this assay, from the lowest: compound 1; then compound 3; then compound 2.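

Among the compounds shown here, compound 3 gives the first step that can be read as one change in one place: isopropyl in place of hydrogen on an aromatic carbon, para to a large group, comes with a number 0.55 log units higher from compound 1 to compound 3 (beyond the scatter) in this assay. This step is modest but beyond the scatter, so a single group made only of carbon, placed on the six-membered aromatic ring of compound 1, is enough to produce a readable change in this measurement. Nothing available here explains why the step has this size, and no independent measurement bears on the result.

With only this one substitution, the compounds shown leave open how much of the step belongs to the isopropyl group itself and how much to its place on the ring, since no other group at this position and no isopropyl group at another ring position appears among them. They also leave open whether a longer chain at the same position would raise the number further, and how far an amine or a carboxylic acid there would move it, and in which direction.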